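The source may hold more compounds than are shown below. What is called first, only, known or untested is meant among the compounds shown, and "the series" means these compounds.

Measured in a functional assay on MDA-MB-231 cells (Homo sapiens) for antiproliferative activity, read by MTT assay, with a stated time of 48 h; on this read-out higher numbers stand for weaker inhibition of growth and lower numbers for stronger inhibition of growth:
- Compound 1 `COc1ccc(/C=C2\Cc3cc(OC)c(OC)c(OC)c3C2=O)cc1O`: > 10000 nM, a limit.
- Compound 2 `COc1ccc(/C=C2\Cc3cc(OC)c(OC)c(OC)c3C2=O)cc1[N+](=O)[O-]`: > 10000 nM, a limit.
- Compound 3 `COc1ccc(/C=C2\CCc3c(cc(OC)c(OC)c3OC)C2=O)cc1`: 38700 nM.

Compound 3 is the only one of the three with an actual number. The other two values sit at the limit of > 10000 nM in this assay, at which 2 of the 3 values shown sit. Compound 4 `COc1ccc(/C=C2\CCc3c(cc(OC)c(OC)c3OC)C2=O)cc1F` follows from compound 3 by fluoro in place of hydrogen on an aromatic carbon, with 4-methoxyphenyl becoming 3-fluoro-4-methoxyphenyl. Among the compounds with values here, the one measured step is a step that the two limits leave unreadable from compound 1 to compound 2, and it gives no size to carry over. Within the data shown here, no measured step shows what fluoro in place of hydrogen does here, so no shift beyond the scatter is expected in this assay. The expected change is a 1.1-fold lower number from compound 3 to compound 4 (0.04 log units; within the scatter). For compound 4 the estimated value is 35000 nM, with an expected range of 15000 nM to 80000 nM.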

Compound 4, concentration for 50% growth inhibition: 29400 nM
Estimate against measurement, compound 4: 1.2-fold (0.08 log units) above, and the stated range covers the measured number.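

In this assay, within the data shown here, fluoro in place of hydrogen on an aromatic carbon, ortho to the methoxy group, gives the first step that can be read: a 1.3-fold lower number from compound 3 to compound 4 (0.12 log units; within the scatter). So 3-fluoro-4-methoxyphenyl in place of 4-methoxyphenyl moves the number no further than the scatter, whereas the earlier step between two limits cannot be read. Nothing shown here gives a cause for this step.

The compounds shown leave open whether an amine, a carboxylic acid or chloro on this carbon would move the number beyond the scatter.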